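This account rests on a few compounds, and the source may have more. Where it says the series, first, only, none or still open, it means among the compounds named here.

Measured compounds:
Compound 1 `CCOC(=O)c1c(-c2c(Cl)c3ccccc3oc2=O)nn(-c2ccccc2)c1C(=O)OCC`: 48000 nM in a functional assay on DU-145 cells (Homo sapiens) for cytotoxicity, read by MTT assay, with a stated time of 48 h; a higher number here means a weaker inhibitor, a lower number a stronger inhibitor
Compound 2 `CCOC(=O)c1c(-c2cc3ccccc3oc2=O)nn(-c2ccccc2)c1C(=O)OCC`: 57000 nM
Compound 3 `COC(=O)c1c(-c2cc3ccccc3oc2=O)nn(-c2ccccc2)c1C(=O)OC`: 30000 nM

Compound 2 has the highest of these three numbers in this assay, yet the gaps to compound 1 and to compound 3 both fall within the usual scatter, so the three compounds cannot be told apart on these data. Compound 4 `CCOC(=O)c1c(-c2cc3ccccc3oc2=O)nn(-c2cccc(Cl)c2)c1C(=O)OCC` differs from compound 2 by one change: chloro in place of hydrogen on an aromatic carbon. Within the data shown here, only one measured step involves a chloro at all, a 1.2-fold higher number from compound 1 to compound 2 (0.07 log units; within the scatter), and that chloro sat on a different ring; no measured pair shows a chloro entering the phenyl ring attached to the core. Among the measured compounds shown here, with the only related step within the scatter and no direct precedent, the expectation is no shift beyond the scatter in this assay. The estimate for compound 4 is therefore 50000 nM, with a range from 20000 nM to 150000 nM, an expected step of a 1.1-fold lower number from compound 2 to compound 4 (0.06 log units; within the scatter).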

Compound 4, half-maximal inhibitory concentration: 35000 nM
Estimate against measurement, compound 4: 1.4-fold (0.15 log units) above; measured number inside the range.
By their numbers in this assay, from the lowest: compounds 3, 4, 1 and 2 (each within the scatter of the next).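

Among these compounds, this is the first measured change on the phenyl ring attached to the shared core. In this assay, going from phenyl to 3-chlorophenyl gives a 1.6-fold lower number from compound 2 to compound 4 (0.21 log units; within the scatter), so a chloro at this place, meta to a large group, produces no shift that can be told from repeat-measurement noise; the earlier step on a different ring, a 1.2-fold higher number from compound 1 to compound 2 (0.07 log units; within the scatter), does not leave the scatter either. Nothing measured here offers an explanation for this result.

On these data alone, it remains open whether a different group at this place, such as an amine or a carboxylic acid, would move the number beyond the scatter. Also open, as far as these compounds go, is whether a chloro elsewhere on this phenyl ring would behave as it does here.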